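From cycloheptyl to oxolan-3-yl on the shared core

The source may report more compounds than this note shows. Statements on the series, on what has been measured and on what is new or still open speak of the compounds shown alone.

Compound 1 `CN1C(=S)[C@@H](NC(=O)c2nc(Cc3ccccc3)n(C3CCCCC3)n2)COc2ccccc21`: > 100000 nM (a limit)
Compound 2 `CN1C(=S)[C@@H](NC(=O)c2nc(Cc3ccccc3)n(C3CCCCCC3)n2)COc2ccccc21`: > 100000 nM (a limit)
Compound 3 `CN1C(=S)[C@@H](NC(=O)c2nc(Cc3ccccc3)n(C3CCOC3)n2)COc2ccccc21`: not yet measured

Both measured compounds were tested in a toxicity assay on HT-29 cells (Homo sapiens) for cytotoxicity; on this read-out lower numbers stand for higher toxicity in this test and higher numbers for lower toxicity in this test. Compound 1 gives > 100000 nM, which is a limit of the assay and not a number. Compound 2 gives > 100000 nM, which is likewise only a limit. Compound 2 therefore has no readable value, and the whole measured set sits at one point: the limit of > 100000 nM in this assay, at which 2 of the 2 values shown sit.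

Compound 3 carries oxolan-3-yl in place of the cycloheptyl of compound 2 on an aromatic nitrogen: oxolan-3-yl in place of cycloheptyl on an aromatic nitrogen. For the measured compounds named here, only one measured step bears on this change, as it falls at the same aromatic nitrogen, with cycloheptyl in place of cyclohexyl: a step that the two limits leave unreadable from compound 1 to compound 2. That step offers no size to carry over, so no direction can be expected in this assay, and compound 3 is expected to remain at the limit. The estimated value for compound 3 is 100000 nM, with an expected range of 30000 nM to 300000 nM. The estimate means an expected a number no higher from compound 2 to compound 3 (the limit leaves the size open).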

Compound 3, half-maximal cytotoxic concentration: > 100000 nM
Compound 3 gave a limit, no number; the forecaster's own chance of this, stated with the estimate: 90%; the middle value lies on the limit itself.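

Compound 3 also ends at a limit of this assay and gives no number. For the compounds shown here, no step among compound 1, compound 2 and compound 3 can therefore be read. The compounds shown leave open whether cyclohexyl, cycloheptyl and oxolan-3-yl on the aromatic nitrogen differ at all in this assay, and in which direction any difference would run.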